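Replacing a terminal hydroxy on the side chain of compound 1

The source may report more compounds than this note shows. Statements on the series, on what has been measured and on what is new or still open speak of the compounds shown alone.

Measured compounds:
Compound 1 `CC(C)(C)C(=O)C1=C(O)C(=O)N(c2ccc(-c3ccsc3)cc2)C1c1ccccc1OCCO` — 3.3 h
Compound 2 `CC(C)(C)C(=O)C1=C(O)C(=O)N(c2ccc(-c3cccs3)cc2)C1c1ccccc1OCCO` — 2 h

Both compounds were tested in an ADME assay on the whole organism (Rattus norvegicus) for metabolic stability; a lower number here means that the compound disappears faster, a higher number that the compound lasts longer. For the measured compounds named here, compound 1 gives 3.3 h, the higher of the two numbers; the only step recorded, a 1.7-fold lower number from compound 1 to compound 2 (0.22 log units; within the scatter), lies within the scatter, so compound 1 and compound 2 cannot be told apart on these numbers.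

Compound 3 `C[S+]([O-])CCOc1ccccc1C1C(C(=O)C(C)(C)C)=C(O)C(=O)N1c1ccc(-c2ccsc2)cc1` has not yet been measured. It differs from compound 1 in one place: a group of 3 heavy atoms (1 carbon, 1 oxygen, 1 sulfur; no ring) in place of one oxygen atom, on a saturated chain carbon, two bonds along the chain from an oxygen on an aromatic ring. Going by the values given here, the one measured step, from compound 1 to compound 2, changes a different part of the molecule, the attachment of the thiophene ring on the far side of the shared core, and so says nothing about the side chain that is altered here. Among the compounds with values here, no measured step bears on the change from compound 1 to compound 3.

With nothing to point in either direction, the expectation is a step from compound 1 to compound 3 of no more than the scatter, a 1.1-fold lower number from compound 1 to compound 3 (0.04 log units; within the scatter). Compound 3 is therefore estimated at 3 h, with a range from 1.2 h to 7 h.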

Compound 3, half-life: 1.4 h
Beside the measured number, compound 3's estimate is 2.1-fold (0.33 log units) above it; low and high end bracket the measured number.
By their numbers in this assay, from the lowest: compounds 3, 2 and 1 (each within the scatter of the next, the first and the last beyond it).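

In this assay the side chain is not a neutral place for change: a group of 3 heavy atoms (1 carbon, 1 oxygen, 1 sulfur) in place of the hydroxy, on a saturated chain carbon, gives a 2.4-fold lower number from compound 1 to compound 3 (0.37 log units; beyond the scatter) and so moves the half-life by a modest but readable amount. The only earlier step lay within the scatter and concerned the thiophene attachment, so this is the one step shown that separates two compounds on their numbers. The swap also takes the count of hydrogen-bond donors in the changed group from 1 to 0, but no measurement shown gives a cause for the step.

One pair cannot say whether the hydroxy itself matters or whether almost any replacement at this place would give a similar step, and a methyl ether, an amine, a carboxylic acid or a longer chain ending in hydroxy would each test that from a different side. From the compounds shown here alone, it also remains open whether the same swap gives a step of similar size on compound 2, which carries thiophen-2-yl in place of thiophen-3-yl.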